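This account rests on a few compounds, and the source may have more. Where it says the series, first, only, none or still open, it means among the compounds named here.

Measured so far:
- compound 1, `CCCCCCCCNC(=O)[C@@H](NC(=O)c1ccccc1)[C@@H](C)O`: 61300 nM in a functional assay on A-431 cells (Homo sapiens) for cytotoxicity, read by MTT assay, with a stated time of 48 h; a lower number here means a stronger inhibitor, a higher number a weaker inhibitor
- compound 2, `CCCCCCCCNC(=O)[C@@H](NC(=O)c1nccc2ccccc12)[C@@H](C)O`: 26900 nM

Compound 1 carries the higher of the two numbers, so of these two it is the weaker inhibitor of the cells. Compound 2 sits lower, and the gap between them is beyond the scatter of repeated measurements, so the difference can be taken as real. Both numbers are high, meaning that neither compound is a potent cytotoxic agent in this assay.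

The next compound, compound 3, `CCCCCCCCNC(=O)[C@@H](NC(=O)/C=C/c1ccccc1)[C@@H](C)O`, keeps the whole of compound 1 except for one change: 2-phenylethenyl in place of phenyl on a carbonyl carbon. The amide linkage, the octyl chain and the rest of the core are untouched.

Among the measured compounds shown here, no measured pair shows exactly this kind of change, so any expectation rests on compound 2 alone, whose 26900 nM shows that altering the aromatic part of the amide can shift the number by a modest amount. A small move towards a lower number is expected, possibly within the scatter. Compound 3 is therefore estimated at 40000 nM, with a range from 15000 nM to 100000 nM. The expected step is a 1.5-fold lower number from compound 1 to compound 3 (0.19 log units; within the scatter).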

Compound 3, half-maximal inhibitory concentration: 36000 nM
Compound 3: middle estimate off by 1.1-fold (0.05 log units), on the high side; measured number inside the range.
By their numbers in this assay, from the lowest: compounds 2, 3 and 1 (each within the scatter of the next, the first and the last beyond it).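

In this assay, 2-phenylethenyl in place of phenyl on a carbonyl carbon gives a 1.7-fold lower number from compound 1 to compound 3 (0.23 log units; within the scatter). Among the compounds shown here, this is the first view of what happens when a double bond outside the aromatic ring is added to the group at this position while the six-membered aromatic ring is kept: the larger group is tolerated, but the number cannot be told apart from that of compound 1, and compound 3, at 36000 nM, is still far from a potent cytotoxic agent. Nothing measured here offers an explanation for this result.

Going by these compounds, it remains open whether the double bond itself matters, which 2-phenylethyl on the same carbonyl carbon could help to test, and whether a group bearing an amine or a carboxylic acid at this position would move the number beyond the scatter. All the compounds shown also carry the octyl chain, so the effect of a longer chain in its place is another open question.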